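The source may report more compounds than this note shows. Statements on the series, on what has been measured and on what is new or still open speak of the compounds shown alone.

Measured so far:
compound 1, `Cc1ccc(NC(=O)c2ccc(C(F)(F)F)cc2)cc1-n1cc(-c2cnc3cccnn23)cn1`: in a functional assay on K562 cells (Homo sapiens) for antiproliferative activity, read by CCK-8 assay, with a stated time of 24 h (a lower number here means a stronger inhibitor, a higher number a weaker inhibitor), compound 1 gives 10500 nM
compound 2, `Cc1ccc(NC(=O)c2ccc(F)cc2)cc1-n1cc(-c2cnc3cccnn23)cn1`: in this assay compound 2 gives 12400 nM

Within the data shown here, compound 2 has the highest of these two numbers, and its nearest neighbour is compound 1; the only measured step, a 1.2-fold higher number from compound 1 to compound 2 (0.07 log units; within the scatter), comes from putting fluoro in place of trifluoromethyl on an aromatic carbon and stays within the scatter. On this evidence the two compounds are indistinguishable.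

Compound 3, `Cc1ccc(NC(=O)c2ccc(CN3CCN(C)CC3)cc2)cc1-n1cc(-c2cnc3cccnn23)cn1`, has not yet been measured. It differs from compound 2 in one place: (4-methylpiperazin-1-yl)methyl in place of fluoro on an aromatic carbon. Among the measured compounds shown here, no measured step involves this new group, so the single known step, a small one at the same aromatic carbon, bears on it only loosely and gives no firm direction. The entering group is much larger than the fluoro it replaces, so a change beyond the scatter is plausible, but its direction rests on no measurement here. Compound 3 is expected to give a somewhat lower number, an expected step of a 2.5-fold lower number from compound 2 to compound 3 (0.39 log units; beyond the scatter). For compound 3 the estimate in this assay is 5000 nM, with a range from 1000 nM to 25000 nM.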

Compound 3, half-maximal inhibitory concentration: < 2 nM
Compound 3 gave a limit, no number (the forecaster's own chance of this, stated with the estimate: 5%); at least 2500-fold (3.39 log units) between middle value and limit.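

The earlier pair showed only that fluoro and trifluoromethyl could not be told apart at this aromatic carbon, which left open whether the position responds to its substituent at all. Compound 3 shows that it can respond strongly: in this assay, (4-methylpiperazin-1-yl)methyl in place of fluoro gives an at least 6200-fold lower number from compound 2 to compound 3 (3.79 log units; beyond the scatter), and in place of trifluoromethyl it gives an at least 5200-fold lower number from compound 1 to compound 3 (3.72 log units; beyond the scatter), so a change at this one carbon can turn a weak inhibitor into a very strong one. The value of compound 3 is a limit of the assay and not a number, so each of these steps gives only a minimum size: the limit of < 2 nM in this assay, at which 1 of the 3 values shown sits.

The compounds shown do not separate the parts of the entering group, since the ring, its two nitrogens, its methyl and the connecting carbon all arrive together, so any one of them or their combination could carry the change. Going by these compounds, a piperazine without its methyl, a morpholine ring or a simple dimethylamine on the same connecting carbon would be needed to tell which part matters, and how far the activity extends beyond the limit stays unknown.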